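The compounds below may be only part of what the source reports. "The series", "measured", "known", "first", "only" and "open" are said of these compounds alone.

Of the compounds shown here, two have been measured so far. Compound 1 `CCC1C(=O)N(C)c2cnc(Nc3ccc(S(=O)(=O)NCCO)cc3)nc2N1c1ccn(C)n1` gives 478 nM in an assay for inhibition of serine/threonine-protein kinase PLK2 (Homo sapiens), read by FRET and Z'-LYTE, with a stated time of 1 h (on this read-out lower numbers stand for stronger inhibition and higher numbers for weaker inhibition), the higher of the two numbers recorded. Compound 2 `CCCCNC(=O)c1ccc2c(ccn2-c2ncc3c(n2)N(c2ccn(C)n2)C(CC)C(=O)N3C)c1` gives 159 nM in this assay; the gap between compound 2 and compound 1 lies beyond the usual scatter, but the two differ in several places at once, so no single change accounts for it.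

The next compound, compound 3 `CCC1C(=O)N(C)c2cnc(Nc3ccc(S(=O)(=O)NCCCO)cc3)nc2N1c1ccn(C)n1`, differs from compound 1 in one place only: hydroxymethyl in place of hydroxy on a saturated chain carbon, two bonds along the chain from a sulfonamide nitrogen. The change stays on the saturated chain attached to the sulfonamide nitrogen and leaves the shared core untouched. Among the measured compounds shown here, no measured pair isolates this change, so nothing here shows which way it moves the number.

The step from compound 1 to compound 3 is expected to be a 1.1-fold lower number from compound 1 to compound 3 (0.03 log units; within the scatter), that is, no shift beyond the scatter in either direction. Compound 3 is therefore estimated at 450 nM in this assay, within a range of 200 nM to 1000 nM.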

Compound 3, half-maximal inhibitory concentration: 192 nM
Estimate against measurement, compound 3: 2.3-fold (0.37 log units) above, and the stated range ends above it.
By their numbers in this assay, from the lowest: compounds 2 and 3 (each within the scatter of the next); then compound 1.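

The saturated chain on the sulfonamide nitrogen is not a silent position in this assay: extending 2-hydroxyethyl to 3-hydroxypropyl, with the shared core untouched, gives a 2.5-fold lower number from compound 1 to compound 3 (0.40 log units; beyond the scatter). Among the compounds shown here, this is the first change isolated at a single place, and it shows that the number responds to chain length alone, since the leaving and entering groups have the same hydrogen-bond donor and acceptor counts and no net charge. Nothing available bears on why the number moves.

Going by these compounds, a single pair gives a step, not a trend, so it remains open whether a longer chain carrying the same terminal hydroxy would continue the shift or reverse it. Also open, on these data alone, is whether the terminal hydroxy is needed at all, which an amine, a carboxylic acid or a plain propyl chain at this position would test.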